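A few compounds are considered here, and "the series" means these few. Any claim that something is new, unique, unknown or untested is made for them only; others in the source may bear on it.

Working notes on the series.

Of the compounds shown here, three share a core and have been measured in a physicochemical assay for lipophilicity, read by HPLC, at pH 7.5; a lower number here means a more polar compound, a higher number a more lipophilic compound. Compound 1 `CCOc1ccccc1-c1ccc(-c2nc3cnccc3c(NC(C)C(=O)O)c2C#N)cc1` gives 2.1 in this assay. Compound 2 `CC[C@@H](Nc1c(C#N)c(-c2ccc(Br)cc2)nc2cnccc12)C(=O)O`, which carries a bromophenyl on the core, gives 1.6. Compound 3 `CC[C@@H](Nc1c(C#N)c(-c2ccc(-c3cccc(Cl)c3OC)cc2)nc2cnccc12)C(N)=O`, carrying an amide in place of the acid of the first two and a 3-chloro-2-methoxyphenyl on the distal ring, gives 3.1. Compound 3 stands highest of the three numbers; the nearest is compound 1, lower and beyond the scatter, and the furthest is compound 2, beyond the scatter as well. Among the compounds with values here, no two of the measured compounds differ in a single place, so no step between measured compounds can be read off directly.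

Compound 4 `CC[C@@H](Nc1c(C#N)c(-c2ccc(-c3cccc(Cl)c3)cc2)nc2cnccc12)C(N)=O` has not been measured yet. It differs from compound 3 in one place: hydrogen in place of methoxy on an aromatic carbon

The group that leaves is small and counts one hydrogen-bond acceptor and no donor, and it sits ortho to a chloro group and ortho to a large group. With nothing in the measured set that isolates this change, the expectation rests on the change alone: a step no larger than the scatter, slightly downward if anything, is expected from compound 3 to compound 4, a number 0.10 log units lower from compound 3 to compound 4 (within the scatter). For compound 4 the value in this assay is estimated at 3, with a range from 2.6 to 3.5.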

Compound 4, distribution coefficient: 3.1
Beside the measured number, compound 4's estimate is 0.10 log units below it; low and high end bracket the measured number.
By their numbers in this assay, from the lowest: compound 2; then compound 1; then compounds 3 and 4 (each within the scatter of the next).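

Within the data shown here, the first comparison that isolates a single place reads, in this assay, no change at the digits printed from compound 3 to compound 4 (within the scatter). Among these compounds, this places a limit on the position: on this aromatic carbon, ortho to a chloro group and ortho to a large group, with the amide on the side chain, going from 3-chloro-2-methoxyphenyl to 3-chlorophenyl removes two heavy atoms and a hydrogen-bond acceptor without moving the reading beyond the scatter, something the earlier compounds, which differ in several places at once, could not show. Nothing available gives a reason for this outcome.

The compounds shown leave open whether a hydroxyl group, an amine or a fluorine on the same carbon would also stay within the scatter of compound 3, since methoxy and hydrogen are the only two groups compared there. They also leave open whether the same exchange would read alike with a carboxylic acid in place of the amide, or with the chloro group replaced by a methyl group or by hydrogen.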